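The compounds below may be only part of what the source reports. "The series", "measured", "known", "first", "only" and "open" are said of these compounds alone.

Measured so far in a functional assay on the whole organism with Rattus norvegicus as the target; a lower number here means that less compound is needed, a higher number that more compound is needed for the effect:

Compound 1, `C/N=C(/NC#N)NCCCCCCn1nc(-c2ccccc2)ccc1=O`, gives a limit of > 100 mg/kg in this assay.

Compound 2, `CC/N=C(/NC#N)NCCCn1nc(-c2ccccc2)ccc1=O`, gives 88.5 mg/kg in this assay.

Among the measured compounds shown here, compound 2 therefore stands on the only number this assay has produced here; the other result, that of compound 1, is the limit of > 100 mg/kg in this assay, at which 1 of the 2 values shown sits. Compound 3, `C/N=C(\NC#N)NCCCCn1nc(-c2ccccc2)ccc1=O`, has not been measured in this assay. It differs from compound 2 by a group of 8 heavy atoms (4 carbon, 4 nitrogen; no ring) in place of a group of 8 heavy atoms (4 carbon, 4 nitrogen; no ring), on a saturated chain carbon, three bonds along the chain from an aromatic nitrogen. For the measured compounds named here, no step between measured compounds is given, so the size of the step from compound 2 to compound 3 can only be guessed; the expectation is a small step in this assay, if any, not clearly beyond the usual scatter, with a real chance that the assay reports only a limit. The dose for compound 3 is estimated at 100 mg/kg, with a range from 50 mg/kg to 200 mg/kg, which means an expected step of a 1.1-fold higher number from compound 2 to compound 3 (0.05 log units; within the scatter).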

Compound 3, dose for half-maximal effect: 38.5 mg/kg
Beside the measured number, compound 3's estimate is 2.6-fold (0.41 log units) above it, and the stated range ends above it.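

In this assay, among the compounds shown here, the position three bonds along the chain from an aromatic nitrogen proves sensitive to how its group is put together, which the earlier compounds could not show, as no step among them could be read. Both groups hold 8 heavy atoms (4 carbon, 4 nitrogen; no ring) with the same counts of double and triple bonds, donors and acceptors, yet the dose moves beyond the scatter, with a 2.3-fold lower number from compound 2 to compound 3 (0.36 log units; beyond the scatter). Compound 1 gives only a limit: the limit of > 100 mg/kg in this assay, at which 1 of the 3 values shown sits.

Steps involving compound 1 therefore cannot be read, and this single modest step cannot separate the parts of the rearranged group from one another. From the compounds shown here alone, whether an amine or a carboxylic acid at this place would keep, lose or extend the lower dose stays open.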